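Triazole amide on the monochlorophenyl core: expected potency

The source may report more compounds than this note shows. Statements on the series, on what has been measured and on what is new or still open speak of the compounds shown alone.

Measured so far, in a functional assay (aorta) with Rattus norvegicus as the target; on this read-out higher numbers stand for weaker inhibition and lower numbers for stronger inhibition:
- compound 1 `CCO/C(O)=C1\C(COCCn2cc(C(N)=O)nn2)=NC(C)=C(C(=O)OC)C1c1cccc(Cl)c1Cl`: 3.16 nM
- compound 2 `CCO/C(O)=C1\C(COCCn2c(C)nc(C)c2C)=NC(C)=C(C(=O)OC)C1c1ccccc1Cl`: 5.01 nM
- compound 3 `CCOC(=O)c1cnnn1CCOCC1=NC(C)=C(C(=O)OC)C(c2ccccc2Cl)/C1=C(\O)OCC`: 100 nM

Compound 3 gives the highest number of the three in this assay, beyond the scatter from both others; compound 2 is the nearest to it and compound 1 the furthest. Within the data shown here, the one single-point step measured so far runs into compound 3: a 20-fold higher number from compound 2 to compound 3 (1.30 log units; beyond the scatter). That step bears directly on the present question, since it shows the 5-(ethoxycarbonyl)-1H-1,2,3-triazol-1-yl group on this chain position costing a large amount of inhibition against an alternative ring.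

Compound 4 `CCO/C(O)=C1\C(COCCn2cc(C(N)=O)nn2)=NC(C)=C(C(=O)OC)C1c1ccccc1Cl` differs from compound 3 in one place: 4-carbamoyl-1H-1,2,3-triazol-1-yl in place of 5-(ethoxycarbonyl)-1H-1,2,3-triazol-1-yl on a saturated chain carbon, two bonds along the chain from an oxygen on a saturated carbon. Among the measured compounds shown here, the entering group is the one carried by compound 1, which differs from compound 4 only in the aryl substitution, and in this assay compound 1 gives 3.16 nM. Compound 2 and compound 3 share the monochlorophenyl of compound 4. The expected step in this assay is therefore a large drop in number, roughly the reverse of the step into compound 3: a 20-fold lower number from compound 3 to compound 4 (1.30 log units; beyond the scatter) is the estimate. Compound 4 is estimated at 5 nM, with a range of 2 nM to 16 nM, because compound 1 with the same triazole amide gives 3.16 nM.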

Compound 4, half-maximal inhibitory concentration: 20 nM
Beside the measured number, compound 4's estimate is 4.0-fold (0.60 log units) below it; the measured number lies above the stated range.
By their numbers in this assay, from the lowest: compounds 1 and 2 (each within the scatter of the next); then compound 4; then compound 3.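

In this assay, the triazole at this chain position is not uniformly costly: the step of a 5.0-fold lower number from compound 3 to compound 4 (0.70 log units; beyond the scatter) shows that 4-carbamoyl-1H-1,2,3-triazol-1-yl recovers part of the inhibition, while the step of a 4.0-fold higher number from compound 2 to compound 4 (0.60 log units; beyond the scatter) leaves it short of 2,4,5-trimethyl-1H-imidazol-1-yl on the same monochlorophenyl core. The value of the triazole amide also depends on the aryl substitution, as hydrogen in place of chloro on an aromatic carbon gives the step of a 6.3-fold higher number from compound 1 to compound 4 (0.80 log units; beyond the scatter), so the number of the dichlorophenyl compound does not carry over to the monochlorophenyl one. No supporting data are available to explain any of these steps.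

The step from 5-(ethoxycarbonyl)-1H-1,2,3-triazol-1-yl to 4-carbamoyl-1H-1,2,3-triazol-1-yl changes both the substituent and its place on the triazole, so the compounds shown do not separate the two; 4-(ethoxycarbonyl)-1H-1,2,3-triazol-1-yl and 5-carbamoyl-1H-1,2,3-triazol-1-yl would divide that step. Going by these compounds, it also remains open whether the chloro step holds with 2,4,5-trimethyl-1H-imidazol-1-yl on the chain, and how a carboxylic acid on the triazole would read.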